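Chlorophenyl swap: working notes toward compound 4

This account rests on a few compounds, and the source may have more. Where it says the series, first, only, none or still open, it means among the compounds named here.

Measured so far in a functional assay on MCF7 cells (Homo sapiens) for cytotoxicity, read by ELISA, with a stated time of 4 days; a lower number here means a stronger inhibitor, a higher number a weaker inhibitor:
compound 1, `Clc1cccc(-c2cc(-c3ccoc3)cc(-c3ccc(Cl)s3)n2)c1`, gives 2920 nM
compound 2, `Clc1ccc(-c2cc(-c3ccoc3)cc(-c3ccc(Cl)s3)n2)cc1`, gives 2600 nM
compound 3, `Clc1cccc(-c2cc(-c3ccc(Cl)o3)cc(-c3ccc(Cl)s3)n2)c1`, gives 15100 nM

Compound 4, `Clc1ccc(-c2cc(-c3ccc(Cl)o3)cc(-c3ccc(Cl)s3)n2)cc1`, is not yet measured. It differs from compound 3 by 4-chlorophenyl in place of 3-chlorophenyl on an aromatic carbon. The same kind of change has been measured once already, from compound 1 to compound 2, as 4-chlorophenyl in place of 3-chlorophenyl on an aromatic carbon, giving a 1.1-fold lower number from compound 1 to compound 2 (0.05 log units; within the scatter). The two cores differ by 5-chlorofuran-2-yl in place of furan-3-yl on an aromatic carbon, a change that gave a 5.2-fold higher number from compound 1 to compound 3 (0.71 log units; beyond the scatter). The surroundings of the place are not identical: in compound 1 the site is meta to a furan-3-yl group, in compound 3 meta to a 5-chlorofuran-2-yl group, so this is the same kind of change, not the same change. For the measured compounds named here, for compound 4 the expected step is a 1.1-fold lower number from compound 3 to compound 4 (0.03 log units; within the scatter), resting on the single earlier step of a 1.1-fold lower number from compound 1 to compound 2 (0.05 log units; within the scatter). Compound 4 is therefore estimated at 14000 nM, between 6000 nM and 35000 nM.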

Compound 4, half-maximal inhibitory concentration: 12600 nM
Estimate against measurement, compound 4: 1.1-fold (0.05 log units) above; low and high end bracket the measured number.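

In this assay, the swap of 3-chlorophenyl for 4-chlorophenyl gives a 1.2-fold lower number from compound 3 to compound 4 (0.08 log units; within the scatter), and it carries from one core to the other without a detectable difference: the same change on two cores in this assay, a 1.1-fold lower number (0.05 log units; within the scatter) from compound 1 to compound 2 and a 1.2-fold lower number (0.08 log units; within the scatter) from compound 3 to compound 4, 1.1-fold (0.03 log units) apart, within the scatter of two such steps. The swap of furan-3-yl for 5-chlorofuran-2-yl gives a 4.8-fold higher number from compound 2 to compound 4 (0.69 log units; beyond the scatter), and it also holds with either chlorophenyl group: the same change on two cores in this assay, a 5.2-fold higher number (0.71 log units; beyond the scatter) from compound 1 to compound 3 and a 4.8-fold higher number (0.69 log units; beyond the scatter) from compound 2 to compound 4, 1.1-fold (0.03 log units) apart, within the scatter of two such steps. This rests on a single set of four compounds in one assay, so it does not show that either change would carry to other cores or other read-outs.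

Still open, going by these compounds, is how the series responds to a group other than chlorine on the phenyl ring, such as an amine or a carboxylic acid. The furan step also changes the chlorine and the point of attachment together, and the compounds shown do not separate the two.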